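The source may report more compounds than this note shows. Statements on the series, on what has been measured and on what is new or still open speak of the compounds shown alone.

Measured so far in an ADME assay on CCRF-HSB-2 cells (Homo sapiens) for cytotoxicity, with a stated time of 7 days; on this read-out higher numbers stand for lower toxicity in this test and lower numbers for higher toxicity in this test:
- compound 1 `COCCOc1nc(N)nc2c1ncn2/C=C1/CC1(CO)CO`: > 20000 nM (a limit of the assay)
- compound 2 `Nc1nc(N2CCCC2)c2ncn(/C=C3/CC3(CO)CO)c2n1`: > 20000 nM (a limit of the assay)
- compound 3 `CCCCCCSc1nc(N)nc2c1ncn2/C=C1/CC1(CO)CO`: 60000 nM (a number)

For the measured compounds named here, compound 3 gives 60000 nM, the only true number in the set. Compound 1 and compound 2 both stand at the limit of > 20000 nM in this assay, at which 2 of the 3 values shown sit, so compound 3 cannot be ranked against either of them.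

The next compound is compound 4 `CCCCSc1nc(N)nc2c1ncn2/C=C1/CC1(CO)CO`. The change is hydrogen in place of ethyl on a saturated chain carbon, four bonds along the chain from a sulfur. The sulfur-linked chain is kept and only shortened.

Going by the values given here, two measured steps touch the hexylsulfanyl group of compound 3: a step that the limit leaves unreadable from compound 1 to compound 3 and a step that the limit leaves unreadable from compound 2 to compound 3. A third, a step that the two limits leave unreadable from compound 1 to compound 2, does not involve that group. Among the compounds with values here, none of them gives a size, and no measured step shortens a chain, so the data offer no direction for this change.

The working expectation is therefore no step beyond the scatter, anchored on compound 3 at 60000 nM, with a wide margin. There is a real chance that this assay returns only a limit for compound 4. The expected size is no change at the digits printed from compound 3 to compound 4 (within the scatter). For compound 4 the estimated value is 60000 nM, with an expected range of 20000 nM to 150000 nM.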

Compound 4, half-maximal cytotoxic concentration: 89000 nM
For compound 4 the middle estimate is 1.5-fold (0.17 log units) below the measured one; measured number inside the range.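

In this assay, the series now has one readable step, and it falls on the sulfur-linked chain: a 1.5-fold higher number from compound 3 to compound 4 (0.17 log units; within the scatter). The hexylsulfanyl and butylsulfanyl chains therefore cannot be told apart in this test, and hydrogen in place of ethyl on a saturated chain carbon, four bonds along the chain from a sulfur, gives no difference beyond the scatter. The steps to compound 4 from the 2-methoxyethoxy compound 1 and the pyrrolidin-1-yl compound 2 cannot be read, so the sulfur-linked chains still cannot be ranked against those two groups: the limit of > 20000 nM in this assay, at which 2 of the 4 values shown sit.

For the compounds shown here, this single pair covers only two chain lengths, so it remains open whether a methylsulfanyl group or a longer chain such as octylsulfanyl would give a step beyond the scatter. Also open, going by these compounds, is whether a hydroxyl, an amine or a carboxylic acid at the end of the butylsulfanyl chain would shift the read-out of this test.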